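The compounds below may be only part of what the source reports. "The series", "measured", "known", "first", "only" and "open" are said of these compounds alone.

Measured in a functional assay on the whole organism with Mus musculus as the target; a higher number here means that more compound is needed for the effect, a lower number that less compound is needed:
- compound 1 `CCCN(C)C(=O)Cn1c(-c2ccc(Cl)cc2)nc2cccnc21` gives 11.6 mg/kg
- compound 2 `CN(C)CCNC(=O)Cn1c(-c2ccc(Cl)cc2)nc2cccnc21` gives 62 mg/kg
- compound 3 `NC(=O)Cn1c(-c2ccc(Cl)cc2)nc2ccc[n+]([O-])c21` gives 52.1 mg/kg

Compound 3 lies within the usual scatter of compound 2 and needs more compound than compound 1 does. Compound 4 `CN(C)C(=O)Cn1c(-c2ccc(Cl)cc2)nc2ccc[n+]([O-])c21` differs from compound 3 by dimethylamino in place of amino on a carbonyl carbon. Among the measured compounds shown here, the one measured step on such a carbon is a 5.3-fold higher number from compound 1 to compound 2 (0.73 log units; beyond the scatter) as (2-(dimethylamino)ethyl)amino replaces methyl(propyl)amino. Those groups differ from the present pair, and the core of compound 3 differs from that of compound 1, so the guidance is weak. Compound 1, without an amide hydrogen, gives 11.6 mg/kg and so hints at a modest lower number in this assay here. The expected change is a 2.1-fold lower number from compound 3 to compound 4 (0.32 log units; beyond the scatter) with wide uncertainty. For compound 4 the estimate is 25 mg/kg with an expected range from 9 mg/kg to 65 mg/kg in this measurement.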

Compound 4, dose for half-maximal effect: 20 mg/kg
Beside the measured number, compound 4's estimate is 1.3-fold (0.10 log units) above it; the range from low to high includes it.
By their numbers in this assay, from the lowest: compounds 1 and 4 (each within the scatter of the next); then compounds 3 and 2 (each within the scatter of the next).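

In this assay, dimethylamino in place of amino on the carbonyl carbon gives a 2.6-fold lower number from compound 3 to compound 4 (0.42 log units; beyond the scatter). Among the compounds shown here, the only earlier step at such a carbon involved other groups on a different core, so this is the first direct reading of this change on the core of compound 3. Nothing measured here gives a reason for the step.

Methylamino, with a single methyl group on the nitrogen, or a ring amine such as pyrrolidine could show how far this trend extends. From the compounds shown here alone, it also remains open whether the same change would have a similar effect on the core of compound 1.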